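From Phenyl to 2,4-Dichlorophenyl in Compound 3

The source may report more compounds than this note shows. Statements on the series, on what has been measured and on what is new or still open speak of the compounds shown alone.

Compound 1 `CC(C)(C)c1ccc(S(=O)(=O)NC(CC(=O)O)c2ccccc2)cc1`: > 100000 nM
Compound 2 `O=C(O)CC(NS(=O)(=O)c1cc(F)cc(F)c1)c1ccccc1`: 79300 nM

Both results come from a functional assay on MDA-MB-231 cells (Homo sapiens) for antiproliferative activity, read by MTT assay, with a stated time of 24 h; on this read-out lower numbers stand for stronger inhibition and higher numbers for weaker inhibition. Compound 1 reports only a limit of the assay, > 100000 nM, and not a number. For the measured compounds named here, compound 2 gives 79300 nM, the only true number available so far.

The next compound is still unmeasured. Compound 3 `O=C(O)CC(NS(=O)(=O)c1cc(F)cc(F)c1)c1ccc(Cl)cc1Cl` carries 2,4-dichlorophenyl in place of phenyl on a saturated chain carbon bound to a saturated chain carbon and a sulfonamide nitrogen. Going by the values given here, no measured pair of compounds shows what such a swap does in this assay, so any expectation here is cautious. A modest gain in inhibition is expected, an estimated 2.0-fold lower number from compound 2 to compound 3 (0.30 log units; within the scatter). For compound 3 the estimated value is 40000 nM, with an expected range from 12000 nM to 100000 nM.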

Compound 3, half-maximal inhibitory concentration: 35700 nM
Estimate against measurement, compound 3: 1.1-fold (0.05 log units) above; low and high end bracket the measured number.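

In this assay, the phenyl on the saturated chain carbon bound to a saturated chain carbon and a sulfonamide nitrogen proves open to change: 2,4-dichlorophenyl in its place gives a 2.2-fold lower number from compound 2 to compound 3 (0.35 log units; beyond the scatter). For the compounds shown here, this is the first single-place comparison, and the step is modest, though beyond the usual scatter. Compound 1 reports only a limit and not a number: the limit of > 100000 nM in this assay, at which 1 of the 3 values shown sits.

On these data alone, it remains open whether a single chlorine on the phenyl would give the same step, or whether a methoxy group or an amine on that ring would shift the number further. The cause of the step also remains open, since one pair of compounds shows its size but not what lies behind it.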